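The compounds below may be only part of what the source reports. "The series", "measured", "known", "first", "only" and "open" are said of these compounds alone.

Going by the values given here, in a functional assay on SMMC-7721 cells (Homo sapiens) for cytotoxicity, read by MTT assay, with a stated time of 24 h (a higher number here means a weaker inhibitor, a lower number a stronger inhibitor), compound 1 `O=C1/C(=C/c2cccnc2)CN(S(=O)(=O)c2ccc(F)cc2)C/C1=C\c1ccccc1F` gives 9900 nM and compound 2 `O=C1/C(=C/c2cccnc2)CN(S(=O)(=O)c2ccc(Cl)cc2)C/C1=C\c1ccccc1F` gives 16100 nM, so compound 2 stands within the scatter of the only other measured compound. Compound 3 `N#Cc1ccc(S(=O)(=O)N2C/C(=C\c3cccnc3)C(=O)/C(=C/c3ccccc3F)C2)cc1` differs from compound 2 by cyano in place of chloro on an aromatic carbon, with cyano in place of chloro on an aromatic carbon. Among the compounds with values here, the one measured step that bears on this change, a 1.6-fold higher number from compound 1 to compound 2 (0.21 log units; within the scatter), swapped fluoro for chloro and lies within the scatter. One step is thin evidence, but the expected change, a 1.2-fold lower number from compound 2 to compound 3 (0.09 log units; within the scatter), is none beyond the scatter. Compound 3 is estimated at 13000 nM, with an expected range of 6000 nM to 30000 nM.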

Compound 3, half-maximal inhibitory concentration: 15400 nM
Estimate against measurement, compound 3: 1.2-fold (0.07 log units) below; the measured number falls inside the stated range.
By their numbers in this assay, from the lowest: compounds 1, 3 and 2 (each within the scatter of the next).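

In this assay, cyano brings a triple bond and a hydrogen-bond acceptor that chloro does not have, yet the step stays small (a 1.0-fold lower number from compound 2 to compound 3 (0.02 log units; within the scatter)), and the step from fluoro is also within the scatter (a 1.6-fold higher number from compound 1 to compound 3 (0.19 log units; within the scatter)). Fluoro, chloro and cyano on this aromatic carbon, para to a large group, therefore give numbers within the scatter of one another. Nothing measured here speaks to why these numbers stay together. The compounds shown leave open whether an amine or a carboxylic acid at this position would stay within that scatter. They also leave open whether this holds when the shared core is changed elsewhere.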